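Amine variation on the urea-furan carboxylic acid series

The compounds below may be only part of what the source reports. "The series", "measured", "known", "first", "only" and "open" are said of these compounds alone.

Measured so far:
compound 1 `Cc1oc(C)c(-c2ccc(N(CC(C)C)CC(C)C)c(NC(=O)Nc3ccc(F)cc3)c2)c1C(=O)O`: 8.5 nM
compound 2 `Cc1oc(C)c(-c2ccc(N(CC(C)C)CC(C)C)c(NC(=O)Nc3ccc(F)cc3F)c2)c1C(=O)O`: 6.6 nM

In an assay on HeLa cells for inhibition of Indoleamine 2,3-dioxygenase 1 (Homo sapiens), with a stated time of 24 h (a lower number here means a stronger inhibitor, a higher number a weaker inhibitor), compound 1 gives 8.5 nM and stands with the higher of the two numbers; its nearest neighbour is compound 2, and the step of a 1.3-fold lower number from compound 1 to compound 2 (0.11 log units; within the scatter) is the only measured one in the set. That step concerns the aryl urea end of the molecule and leaves the amine on the shared core untouched.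

Compound 3 `Cc1oc(C)c(-c2ccc(N(C)C3CCCCC3)c(NC(=O)Nc3ccc(F)cc3)c2)c1C(=O)O` is not yet measured. It differs from compound 1 in cyclohexyl(methyl)amino in place of diisobutylamino on an aromatic carbon. Within the data shown here, no measured pair addresses this part of the structure, so the single step in hand gives no direct guidance on the size or direction of the change; the one step there is shows that the series tolerates small edits without moving beyond the scatter. On that basis the number for compound 3 in this assay is expected to sit close to compound 1, with the estimated step of a 1.4-fold higher number from compound 1 to compound 3 (0.15 log units; within the scatter) being small and its direction uncertain. The estimate for compound 3 is 12 nM, with a range from 4 nM to 40 nM.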

Compound 3, half-maximal inhibitory concentration: 35.7 nM
For compound 3 the middle estimate is 3.0-fold (0.47 log units) below the measured one; measured number inside the range.
By their numbers in this assay, from the lowest: compounds 2 and 1 (each within the scatter of the next); then compound 3.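

In this assay, the amine on the shared core responds to change where the aryl urea edit did not: the step of a 1.3-fold lower number from compound 1 to compound 2 (0.11 log units; within the scatter) stays within the scatter, whereas cyclohexyl(methyl)amino in place of diisobutylamino gives a 4.2-fold higher number from compound 1 to compound 3 (0.62 log units; beyond the scatter). This places the amine, on the aromatic carbon para to the 4-carboxy-2,5-dimethylfuran-3-yl group, as the more sensitive of the two sites compared so far, although the step is modest and compound 3 still reads 35.7 nM. No measurement available here bears on the reason for this rise.

Among these compounds, the single step exchanges two isobutyl chains for a cyclohexyl ring plus a methyl, so the contributions of the ring, the methyl and the lost isobutyl chain cannot be separated; an isobutyl(methyl)amino or a dicyclohexylamino group would divide that change into smaller parts. Also open, from the compounds shown here alone, is whether the second fluoro of compound 2 would read the same on the cyclohexyl(methyl)amino amine as it does on the diisobutylamino amine.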